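Notes on inverting one ring stereocentre

The source may hold more compounds than are shown below. What is called first, only, known or untested is meant among the compounds shown, and "the series" means these compounds.

In a physicochemical assay for lipophilicity, at pH 7.4 (a higher number here means a more lipophilic compound, a lower number a more polar compound), compound 3 `Cc1cc(C)c(CN2CCc3c(Cl)cc([C@H](CO)[C@H]4CCCO4)c(Cl)c3C2=O)c(=O)[nH]1` gives 2.1, and compound 1 `Cc1cc(C)c(CN2CCc3c(Cl)cc([C@H](CO)[C@H]4CCOC4)c(Cl)c3C2=O)c(=O)[nH]1` gives 2, which lies within the scatter of it. Compound 2 `COC(c1cc(Cl)c2c(c1Cl)C(=O)N(Cc1c(C)cc(C)[nH]c1=O)CC2)C1CCOC1` gives 3; 3; 3; 3 (4 entries) over repeated entries. Compound 4 `Cc1cc(C)c(CN2CCc3c(Cl)cc([C@H](CO)[C@@H]4CCCO4)c(Cl)c3C2=O)c(=O)[nH]1` differs from compound 3 as follows: the two compounds have the same atoms and bonds and differ only in configuration as drawn: 1 of 2 stereo elements differ; a stereocentre at a saturated ring carbon is drawn R in compound 3 and S in compound 4. Among the compounds with values here, the one measured step that bears on this is a number 0.10 log units higher from compound 1 to compound 3 (within the scatter), with oxolan-2-yl in place of oxolan-3-yl, and it stays within the scatter. Within the data shown here, no measured pair isolates a change of configuration alone, so the data give no direction. No step beyond the scatter is expected in this assay. The expected step is no change at the digits printed from compound 3 to compound 4 (within the scatter). Compound 4 is expected at 2.1, with an estimated range of 1.8 to 2.4.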

Compound 4, distribution coefficient: 2.4
The estimate for compound 4 lay 0.30 log units below the measured number; measured number inside the range.
By their numbers in this assay, from the lowest: compounds 1, 3 and 4 (each within the scatter of the next, the first and the last beyond it).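

In this assay, inverting the stereocentre at the saturated ring carbon gives a number 0.30 log units higher from compound 3 to compound 4 (within the scatter), so configuration alone gives no readable separation at this position. Oxolan-2-yl in place of oxolan-3-yl, however, now gives a number 0.40 log units higher from compound 1 to compound 4 (beyond the scatter), the first step at this position that clears the scatter, and it appears only with the ring carbon drawn S. Any gap between the values of this pair can have only one structural source: the fact that compounds 3 and 4 differ only in the configuration as drawn

Open, from the compounds shown here alone, is whether the same inversion in the oxolan-3-yl series gives a readable step. Also open, going by these compounds, is how an amine or a carboxylic acid in place of oxolan-2-yl would read in this assay.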